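Amide nitrogen substituent series: compound 3 to compound 4

The source may report more compounds than this note shows. Statements on the series, on what has been measured and on what is new or still open speak of the compounds shown alone.

Within the data shown here, compound 3 `COC(=O)/C=C/c1cccc(N(C(=O)C2CCCCC2)c2ccc3ccccc3c2)c1` is the only member of the series with a numerical result: in an assay on isolated protein with Bile acid receptor (Homo sapiens) as the target (a lower number here means that less compound is needed, a higher number that more compound is needed for the effect), compound 3 gives 680 nM. Compound 1 `COC(=O)/C=C/c1cccc(N(C)C(=O)C2CCCCC2)c1` sits at a limit of the assay, compound 1 giving > 1000 nM in this assay. Compound 2 `COC(=O)/C=C/c1cccc(N(Cc2ccccc2)C(=O)C2CCCCC2)c1` likewise stands at a limit, compound 2 giving > 1000 nM in this assay. Both limits are the same one, (the limit of > 1000 nM in this assay, at which 2 of the 3 values shown sit). The steps to compound 3 are thus floors only, an at least 1.4-fold lower number from compound 1 to compound 3 (0.16 log units; that floor lies within the scatter) and an at least 1.4-fold lower number from compound 2 to compound 3 (0.16 log units; that floor lies within the scatter), while a step that the two limits leave unreadable from compound 1 to compound 2.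

Compound 4 `COC(=O)/C=C/c1cccc(N(Cc2ccccc2Br)C(=O)C2CCCCC2)c1` is to be measured in this assay. The change is 2-bromobenzyl in place of naphthalen-2-yl on an amide-type nitrogen. The step from compound 2 to compound 3 bears most directly on it: compound 4 carries a 2-bromobenzyl where compound 2 carries a benzyl. That step, an at least 1.4-fold lower number from compound 2 to compound 3 (0.16 log units; that floor lies within the scatter), ran toward a lower number in compound 3, so for compound 4 a move back toward the limit is expected, of a size the floor does not fix. Compound 4 is expected to give 1500 nM in this assay, between 500 nM and 5000 nM. That estimate means a step of a 2.2-fold higher number from compound 3 to compound 4 (0.34 log units; beyond the scatter), with a real chance that only a limit is reported.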

Compound 4, half-maximal effective concentration: > 1000 nM
Compound 4: a limit, no number; the forecaster's own chance of this, stated with the estimate: 55%; the middle value does not contradict the limit.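

Among these compounds, with 2-bromobenzyl in place of naphthalen-2-yl on the amide-type nitrogen, the only reading is a floor, an at least 1.4-fold higher number from compound 3 to compound 4 (0.16 log units; that floor lies within the scatter), so the size of this change remains unfixed. Bromo in place of hydrogen on the aromatic ring of the benzyl group does not yield a numerical result in this assay: compound 4 is at a limit, as are compound 1 and compound 2, and the steps among these three cannot be read. Among the groups shown on this nitrogen, only naphthalen-2-yl, in compound 3, gives a number, and the limit now covers most of the series: the limit of > 1000 nM in this assay, at which 3 of the 4 values shown sit.

From the compounds shown here alone, it remains open whether a plain phenyl on this nitrogen would also give a number. Also open, going by these compounds, is whether an amine or a carboxylic acid on the benzyl ring would bring that group within the measurable range.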